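The compounds below may be only part of what the source reports. "The series", "measured", "known", "first", "only" and "open" are said of these compounds alone.

Compound 3 `CC1=CC[C@@H]([C@@](C)(O)CCCC(C)(C)NC(=S)N/N=C\c2ccc(N(C)C)cc2)CC1` sits at the top of the set: in a functional assay on HT-29 cells (Homo sapiens) for cytotoxicity, read by sulforhodamine B assay (a higher number here means that more compound is tolerated, a lower number that less compound is tolerated), compound 3 gives > 100000 nM, which is a limit of the assay rather than a number (the limit of > 100000 nM in this assay, at which 1 of the 3 values shown sits). Compound 1 `CC1=CC[C@@H]([C@@](C)(O)CCCC(C)(C)NC(=S)N/N=C\c2ccccc2)CC1` gives 57400 nM and compound 2 `CC1=CC[C@@H]([C@@](C)(O)CCCC(C)(C)NC(=S)N/N=C\c2ccc(O)cc2)CC1` gives 58500 nM; the steps of an at least 1.7-fold higher number from compound 1 to compound 3 (0.24 log units; that floor lies within the scatter) and an at least 1.7-fold higher number from compound 2 to compound 3 (0.23 log units; that floor lies within the scatter) are therefore floors only. Compound 4 `CC1=CC[C@@H]([C@@](C)(O)CCCC(C)(C)NC(=S)N/N=C\c2ccccc2Cl)CC1` carries 2-chlorophenyl in place of 4-(dimethylamino)phenyl on a carbon with a double bond to nitrogen. Going by the values given here, no measured step exchanges the dimethylamino group for a chlorine, so the two floors bear on it only by showing that the dimethylamino compound tolerates at least as much as its hydrogen and hydroxy neighbours. Compound 4 is expected to return to the region of compounds 1 and 2, a step of an at least 1.6-fold lower number from compound 3 to compound 4 (0.22 log units; that floor lies within the scatter), with an estimate of 60000 nM between 25000 nM and 150000 nM.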

Compound 4, concentration lethal to 50% of the cells: > 100000 nM
Compound 4: no number, only a limit (the forecaster's own chance of this, stated with the estimate: 30%); at least 1.6-fold (0.22 log units) between middle value and limit.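

In this assay compound 4 gives > 100000 nM, which is a limit of the assay and not a number: the limit of > 100000 nM in this assay, at which 2 of the 4 values shown sit. The 2-chlorophenyl group thus joins 4-(dimethylamino)phenyl at that limit, showing that this position reaches it with more than one group. The readable steps, an at least 1.7-fold higher number from compound 1 to compound 4 (0.24 log units; that floor lies within the scatter) and an at least 1.7-fold higher number from compound 2 to compound 4 (0.23 log units; that floor lies within the scatter), are floors only, and the steps joining the two limits cannot be read.

Going by these compounds, how compound 3 and compound 4 compare remains open. So does what a carboxylic acid or a nitrile on the aromatic ring would give.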